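This account rests on a few compounds, and the source may have more. Where it says the series, first, only, none or still open, it means among the compounds named here.

Of the compounds shown here, three have so far been measured in a functional assay on SMMC-7721 cells (Homo sapiens) for inhibition, read by MTT assay, with a stated time of 72 h, tested at 1 uM; on this read-out lower numbers stand for a weaker effect and higher numbers for a stronger effect at the one concentration tested. Compound 1 `Cc1cccc(COc2ccc(/C=C/C(/C=C/c3ccccn3)=N/Oc3ncnc4cccc(C)c34)cc2)c1` gives 93.4%, compound 2 `Cc1cccc(COc2ccc(/C=C/C(/C=C/c3ccccn3)=N/Oc3ncnc4ccccc34)cc2)c1` gives 69.2%, and compound 3 `Cc1cccc2ncnc(O/N=C(\C=C\c3ccccn3)/C=C/c3ccccc3OCc3ccc(Cl)cc3Cl)c12` gives 90.8%. Compound 1 and compound 2 differ in a single place, (hydrogen in place of methyl on an aromatic carbon), and that change made a step of a number 24.2 percentage points lower from compound 1 to compound 2 (beyond the scatter). Compound 3 and compound 1 differ in more than one place; how their two cores differ is not broken down here, and their two values lie within the scatter of each other, so nothing can be said about their order.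

The unmeasured compound 4 `Clc1ccc(COc2ccccc2/C=C/C(/C=C/c2ccccn2)=N/Oc2ncnc3ccccc23)c(Cl)c1` stands to compound 3 as compound 2 stands to compound 1: it carries the same change, (hydrogen in place of methyl on an aromatic carbon), at the same place. Because the same change once gave a number 24.2 percentage points lower from compound 1 to compound 2 (beyond the scatter), compound 4 is expected to take a step of a number 22.8 percentage points lower from compound 3 to compound 4 (beyond the scatter). A single precedent is a thin basis, so the range around the expectation is kept wide. In this assay compound 4 is therefore estimated at about 68%, most likely between 48% and 86%.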

Compound 4, a percentage reported as inhibition, at one concentration (the size of the read-out at that concentration, not a potency): 33.3%
Compound 4: middle estimate off by 34.7 percentage points, on the high side; the whole stated range lies above it.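

In this assay, replacing 5-methylquinazolin-4-yl with quinazolin-4-yl on the second core again lowers the number, this time giving a number 57.5 percentage points lower from compound 3 to compound 4 (beyond the scatter). The direction of the change carried over from one core to the other, but its size did not: the same change on two cores in this assay, a number 24.2 percentage points lower (beyond the scatter) from compound 1 to compound 2 and a number 57.5 percentage points lower (beyond the scatter) from compound 3 to compound 4, 33.3 percentage points apart, beyond the scatter of two such steps Compound 1 and compound 3 differ in more than one place, so these two pairs show that the rest of the molecule matters to the size of this step, but not which part of it does, or why.

At this place the compounds shown carry only methyl or hydrogen, so it remains open how a larger group such as ethyl, or a group such as methoxy or an amine, would read out. Among these compounds, with only two pairs, it also remains open whether the direction would hold on a further core, and how large the step would be there.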